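This account rests on a few compounds, and the source may have more. Where it says the series, first, only, none or still open, it means among the compounds named here.

Working notes on the series: the core stays fixed and the changes fall on the group on an amide-type nitrogen. In an ADME assay on MT4 cells (Homo sapiens) for cytotoxicity, read by MTT assay, with a stated time of 5 days (a lower number here means that less compound is tolerated, a higher number that more compound is tolerated), compound 1 `COc1cc2nc([S+]([O-])CC(=O)Nc3cccc([N+](=O)[O-])c3)nc(Nc3c(Cl)cc(/C=C/C#N)cc3Cl)c2cc1OC` gives >= 83200 nM, which is a limit of the assay and not a number. Compound 2 `COc1cc2nc([S+]([O-])CC(=O)Nc3ccc([N+](=O)[O-])cc3)nc(Nc3c(Cl)cc(/C=C/C#N)cc3Cl)c2cc1OC` gives 92800 nM, and compound 3 `COc1cc2nc([S+]([O-])CC(=O)Nc3cccc(Cl)c3)nc(Nc3c(Cl)cc(/C=C/C#N)cc3Cl)c2cc1OC` gives 68900 nM. Within the data shown here, these are the only two exact numbers so far, and they lie within the scatter of each other, as a 1.3-fold lower number from compound 2 to compound 3 (0.13 log units; within the scatter) shows. Compound 3 therefore stands level with compound 2.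

Next is compound 4 `COc1cc2nc([S+]([O-])CC(=O)Nc3ccc(Cl)cc3)nc(Nc3c(Cl)cc(/C=C/C#N)cc3Cl)c2cc1OC`, with 4-chlorophenyl in place of 3-chlorophenyl on an amide-type nitrogen. The two have the same atoms, joined differently. Among the measured compounds shown here, the closest precedent is the exchange of 3-nitrophenyl for 4-nitrophenyl, but that gives a step that the limit leaves unreadable from compound 1 to compound 2, so it sets no size. The exchange of nitro for chloro gives an at least 1.2-fold lower number from compound 1 to compound 3 (0.08 log units; that floor lies within the scatter), and the step between compound 2 and compound 3 also stays within the scatter. For the measured compounds named here, no measured step supports a shift beyond the scatter in this assay, so none is expected, and no direction is favoured. The estimated change is a 1.1-fold higher number from compound 3 to compound 4 (0.04 log units; within the scatter). The expected value for compound 4 is 75000 nM, with an estimated range from 42000 nM to 115000 nM.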

Compound 4, half-maximal cytotoxic concentration: 14400 nM
Estimate against measurement, compound 4: 5.2-fold (0.72 log units) above; the whole stated range lies above it.
By their numbers in this assay, from the lowest: compound 4; then compounds 3 and 2 (each within the scatter of the next).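

Among these compounds, exchanging 3-chlorophenyl for 4-chlorophenyl on the amide-type nitrogen, with the same atoms joined differently, gives a 4.8-fold lower number from compound 3 to compound 4 (0.68 log units; beyond the scatter) in this assay, so at this place the arrangement of the same atoms alone can move the number beyond the scatter, which no earlier readable step did. The 4-chlorophenyl group also stands apart from both nitrophenyl groups, with a 6.4-fold lower number from compound 2 to compound 4 (0.81 log units; beyond the scatter) and an at least 5.7-fold lower number from compound 1 to compound 4 (0.76 log units; beyond the scatter), making it the only group among those shown with a lower number beyond the scatter. The value of compound 1 is a limit of the assay and not a number: the limit of >= 83200 nM in this assay, at which 1 of the 4 values shown sits.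

From the compounds shown here alone, whether chloro in place of nitro has the same size of effect on the 3-substituted and the 4-substituted phenyl groups stays open: the same change on two cores in this assay, an at least 1.2-fold lower number (0.08 log units; that floor lies within the scatter) from compound 1 to compound 3 and a 6.4-fold lower number (0.81 log units; beyond the scatter) from compound 2 to compound 4; the limit leaves it open whether they differ Also open is whether the lower number belongs to chloro specifically or to 4-substituted phenyl groups more widely, which a 4-fluorophenyl, 4-methoxyphenyl or 4-aminophenyl group on the same amide-type nitrogen could help to separate.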